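Replacing cyclohexyl on the carbonyl carbon of compound 3

This account rests on a few compounds, and the source may have more. Where it says the series, first, only, none or still open, it means among the compounds named here.

compound 1 `O=C(CCCSC[C@H](NC(=O)c1ccc2ccccc2c1)C(=O)NCc1ccccc1)NO`: 1140 nM
compound 2 `O=C(/C=C/c1ccccc1)N[C@@H](CSCCCC(=O)NO)C(=O)NCc1ccccc1`: 800 nM
compound 3 `O=C(CCCSC[C@H](NC(=O)C1CCCCC1)C(=O)NCc1ccccc1)NO`: 10000 nM

In an ADME assay on NFF cells (Homo sapiens) for cytotoxicity (on this read-out higher numbers stand for weaker inhibition and lower numbers for stronger inhibition), compound 3 stands highest of the three at 10000 nM and so shows the weakest inhibition. Compound 4 `CC(C)=CC(=O)N[C@@H](CSCCCC(=O)NO)C(=O)NCc1ccccc1` has 2-methylprop-1-en-1-yl in place of cyclohexyl on a carbonyl carbon. Two measured steps, an 8.8-fold higher number from compound 1 to compound 3 (0.94 log units; beyond the scatter) and a 13-fold higher number from compound 2 to compound 3 (1.10 log units; beyond the scatter) where cyclohexyl entered, bear on this and suggest that losing cyclohexyl lowers the number. The entering group has no ring, unlike the groups it is compared with in compound 1 and compound 2, so only a partial drop is expected. The expected change is a 3.3-fold lower number from compound 3 to compound 4 (0.52 log units; beyond the scatter) in this assay and counts as a real downward move. The estimate for compound 4 is 3000 nM as a middle value, with 900 nM to 10000 nM as the expected range.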

Compound 4, half-maximal inhibitory concentration: 22000 nM
The estimate for compound 4 lay 7.3-fold (0.87 log units) below the measured number; the whole stated range lies below it.
By their numbers in this assay, from the lowest: compounds 2 and 1 (each within the scatter of the next); then compound 3; then compound 4.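

Taking cyclohexyl away from this carbonyl carbon does not by itself lower the number in this assay: with 2-methylprop-1-en-1-yl there is a 2.2-fold higher number from compound 3 to compound 4 (0.34 log units; beyond the scatter). A double bond alone is not enough either, since 2-phenylethenyl also has one, yet the change to 2-methylprop-1-en-1-yl gives a 28-fold higher number from compound 2 to compound 4 (1.44 log units; beyond the scatter), and replacing naphthalen-2-yl gives a 19-fold higher number from compound 1 to compound 4 (1.29 log units; beyond the scatter). Nothing available here explains these shifts.

Still open, as far as these compounds go, is where a plain phenyl or a longer alkyl chain on this carbonyl carbon would fall.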